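Vinyl in place of phenyl on the exocyclic alkylidene

The source may hold more compounds than are shown below. What is called first, only, known or untested is meant among the compounds shown, and "the series" means these compounds.

Going by the values given here, compound 2 `CC1=C/C(=C\c2ccccc2)C(=O)C(C)(O)C12CC2` stands highest of the two numbers so far: in a functional assay on MDA-MB-231 cells (Homo sapiens) for antiproliferative activity (a higher number here means a weaker inhibitor, a lower number a stronger inhibitor), compound 2 gives 4000 nM, while compound 1 `C/C=C1\C=C(C)C2(CC2)C(C)(O)C1=O` gives 110 nM. Among the compounds with values here, the only measured step, a 36-fold higher number from compound 1 to compound 2 (1.56 log units; beyond the scatter), is large. In that step a phenyl stands where compound 1 carries a methyl. Compound 3 `C=C/C=C1\C=C(C)C2(CC2)C(C)(O)C1=O` carries the reverse kind of change, (vinyl in place of phenyl on a double-bonded chain carbon bound to a double-bonded ring carbon), and a vinyl is smaller than a phenyl. A partial return toward compound 1 is therefore expected, and compound 3 is estimated at 500 nM, with a range from 150 nM to 2000 nM, a step of an 8.0-fold lower number from compound 2 to compound 3 (0.90 log units; beyond the scatter).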

Compound 3, half-maximal inhibitory concentration: 28 nM
For compound 3 the middle estimate is 18-fold (1.25 log units) above the measured one; the measured number lies below the stated range.
By their numbers in this assay, from the lowest: compound 3; then compound 1; then compound 2.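

In this assay, the vinyl does more than undo the loss seen with phenyl: it gives a 140-fold lower number from compound 2 to compound 3 (2.15 log units; beyond the scatter), and it also passes the methyl, with a 3.9-fold lower number from compound 1 to compound 3 (0.59 log units; beyond the scatter). At this position, on a double-bonded chain carbon bound to a double-bonded ring carbon, the lowest number of the three therefore belongs to the group with a double bond outside aromatic rings. Nothing available accounts for this order.

The compounds shown leave open whether an ethyl, with the same carbon count as vinyl but no double bond, would match compound 3. They also leave open how a longer chain or an amine would fare here.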